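The source may hold more compounds than are shown below. What is called first, only, known or untested is meant among the compounds shown, and "the series" means these compounds.

Of the compounds shown here, two with the same core have been measured so far in an ADME assay on Ava5 cells (Homo sapiens) for cytotoxicity; a higher number here means that more compound is tolerated, a lower number that less compound is tolerated. Compound 1 `NC(=S)Nc1cccc(OCCCCCc2ccccc2)c1`, whose saturated chain ends in a phenyl, gives 22000 nM. Compound 2 `NC(=S)Nc1cccc(OCCCCCOc2cccnc2)c1` has a (pyridin-3-yl)oxy in place of that phenyl and gives > 50000 nM, which is a limit of the assay and not a number. Compound 2 therefore stands at the limit of > 50000 nM in this assay, at which 1 of the 2 values shown sits.

The next compound, compound 3 `NC(=S)Nc1cccc(OCCCCCOc2ccncc2)c1`, has the same atoms as compound 2, joined differently: pyridin-4-yl in place of pyridin-3-yl on an oxygen on a saturated carbon. The pyridin-4-yl takes the place of the pyridin-3-yl on an oxygen on a saturated carbon, and the rest of the molecule stays the same.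

Among the measured compounds shown here, only one measured step is available, an at least 2.2-fold higher number from compound 1 to compound 2 (0.35 log units; beyond the scatter). For the measured compounds named here, it replaces the phenyl rather than exchanging one pyridinyl group for another, so it bears on this change only indirectly, and no measured step covers the exchange itself. With so little to go on, no step beyond the scatter is expected in this assay, and compound 3 may well reach the same limit. The expected change is a number no higher from compound 2 to compound 3 (the limit leaves the size open). Compound 3 is estimated at 50000 nM, with an expected range from 25000 nM to 100000 nM.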

Compound 3, half-maximal cytotoxic concentration: > 50000 nM
Compound 3: a limit, no number; the forecaster's own chance of this, stated with the estimate: 70%; the middle value lies on the limit itself.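

In this assay, compound 3 gives > 50000 nM, which is a limit of the assay and not a number. Placing (pyridin-4-yl)oxy on the chain in place of phenyl gives an at least 2.2-fold higher number from compound 1 to compound 3 (0.35 log units; beyond the scatter), so this higher number is not tied to the (pyridin-3-yl)oxy group of compound 2 alone: both pyridinyl groups tried on this oxygen share it. The exchange of pyridin-3-yl for pyridin-4-yl itself cannot be read, since the values of compound 2 and compound 3 are both limits and neither gives a number to compare: the limit of > 50000 nM in this assay, at which 2 of the 3 values shown sit.

Any real difference between these two pyridinyl groups stays hidden, and the true tolerated concentrations of compound 2 and compound 3 remain unknown. Replacing phenyl also adds a chain oxygen and a ring nitrogen in one step, so a phenoxy group at the end of the same chain would be needed to show which of the two goes with the higher number seen against compound 1.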